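The source may report more compounds than this note shows. Statements on the series, on what has been measured and on what is new or still open speak of the compounds shown alone.

Series notes: aryl-linked benzylamine phenoxyacetic acids in a functional assay on CHO cells for agonist activity at Free fatty acid receptor 1 (Homo sapiens), read by FLIPR and calcium flux; a higher number here means that more compound is needed for the effect, a lower number that less compound is needed.

Going by the values given here, compound 2 `O=C(O)COc1ccc(NCc2cccc(-c3ccccc3F)c2)cc1F` gives 36.5 nM in this assay, the lowest of the three numbers so far. Compound 1 `Cc1cc(OCCCS(C)(=O)=O)cc(C)c1-c1cccc(CNc2ccc(OCC(=O)O)c(F)c2)c1` gives 59.8 nM in this assay, a gap from compound 2 that sits within the scatter, so the two are read as equivalent. Among the compounds with values here, compound 3 `N#Cc1ccccc1-c1cccc(CNc2ccc(OCC(=O)O)c(F)c2)c1` gives 729 nM in this assay; the single one-place step measured so far, a 20-fold higher number from compound 2 to compound 3 (1.30 log units; beyond the scatter), is the only large move in the set.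

Compound 4 `Cc1cc(O)ccc1-c1cccc(CNc2ccc(OCC(=O)O)c(F)c2)c1` is not yet measured in this assay. It differs from compound 2 as follows: 4-hydroxy-2-methylphenyl in place of 2-fluorophenyl on an aromatic carbon. Within the data shown here, no measured step alters this ring in the same way, so the expectation rests on compound 1, whose value 59.8 nM shows that a larger substituted ring at this position is tolerated, whereas compound 3 shows that the cyano substitution is not. On that basis the step of a 1.9-fold higher number from compound 2 to compound 4 (0.28 log units; within the scatter) is expected to stay within the scatter. Compound 4 is estimated at 70 nM in this assay, with a range of 25 nM to 200 nM.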

Compound 4, half-maximal effective concentration in the Free fatty acid receptor 1 assay: 69.6 nM
The estimate for compound 4 lay 1.0-fold (0.00 log units) above the measured number, and the stated range covers the measured number.
By their numbers in the Free fatty acid receptor 1 assay, from the lowest: compounds 2, 1 and 4 (each within the scatter of the next); then compound 3.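

In the Free fatty acid receptor 1 assay, 4-hydroxy-2-methylphenyl in place of 2-fluorophenyl gives a 1.9-fold higher number from compound 2 to compound 4 (0.28 log units; within the scatter), so this position accepts a ring carrying a hydroxy group, with its hydrogen-bond donor, and no change beyond the scatter. Set against 2-cyanophenyl, the same ring gives a 10-fold lower number from compound 3 to compound 4 (1.02 log units; beyond the scatter) in the Free fatty acid receptor 1 assay, so the high number belongs to the 2-cyanophenyl ring and not to substitution on this ring in general. In a physicochemical assay for lipophilicity, read by HPLC, in phosphate buffer, measured as octanol-water partition, at pH 7.4, tested at 100 uM (a higher number here means a more lipophilic compound, a lower number a more polar compound), compound 2 gives 2.36 and compound 4 gives 1.85. The change also lowers the number in the physicochemical assay while the number in the Free fatty acid receptor 1 assay stays within the scatter: the measured distribution coefficient of compound 2, 2.36, and of compound 4, 1.85, a number 0.51 log units lower (beyond the scatter)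

The hydroxy and methyl groups enter together, so the compounds shown cannot separate their contributions. From the compounds shown here alone, whether an amine or a carboxylic acid in place of the hydroxy group would hold the number in the Free fatty acid receptor 1 assay remains open.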